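The source may hold more compounds than are shown below. What is called first, only, known or untested is meant among the compounds shown, and "the series" means these compounds.

Three compounds built on one shared core were tested in an assay on membranes from CHO cells for displacement of a labelled ligand from adenosine receptor A1 (Homo sapiens), read by scintillation counting, with a stated time of 60 min, tested at 1 uM; on this read-out higher numbers stand for more inhibition at the one concentration tested (going by the name of the read-out) and lower numbers for less inhibition. Compound 1 `CC1=C(C(=O)OC2CCC2)C(c2ccoc2)NC(=O)N1` gives 20% in this assay. Compound 2 `CC1=C(C(=O)OC2CCCC2)C(c2ccoc2)NC(=O)N1` differs from compound 1 by cyclopentyl in place of cyclobutyl on an oxygen next to a carbonyl group; in this assay compound 2 gives 6%, and the step was a number 14 percentage points lower from compound 1 to compound 2 (beyond the scatter). Compound 3 `CC1=C(C(=O)OC2CCC2)C(c2cccs2)NC(=O)N1` differs from compound 1 in its core by thiophen-2-yl in place of furan-3-yl on a saturated ring carbon; in this assay compound 3 gives 24%, and the step was a number 4 percentage points higher from compound 1 to compound 3 (within the scatter), so compound 1 and compound 3 cannot be set apart.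

Compound 4 `CC1=C(C(=O)OC2CCCC2)C(c2cccs2)NC(=O)N1` has not yet been measured. Among the compounds with values here, it differs from compound 3 by cyclopentyl in place of cyclobutyl on an oxygen next to a carbonyl group, which is the same change, made at the same place, as the one from compound 1 to compound 2. Because a number 14 percentage points lower from compound 1 to compound 2 (beyond the scatter), a step of similar size is expected here: a number 14 percentage points lower from compound 3 to compound 4 (beyond the scatter). Compound 4 is therefore expected to give about 10% in this assay, within an expected range from 0% to 22%. This expectation rests on a single earlier example of the change, so it remains uncertain.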

Compound 4, a percentage reported as inhibition, at one concentration (the size of the read-out at that concentration, not a potency): 9%
Compound 4: middle estimate off by 1 percentage points, on the high side; low and high end bracket the measured number.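

Cyclopentyl in place of cyclobutyl on an oxygen next to a carbonyl group again gives a clear drop in this assay, with a number 15 percentage points lower from compound 3 to compound 4 (beyond the scatter), and the size of the step carries over from the furan-3-yl pair to the thiophen-2-yl pair: the same change on two cores in this assay, a number 14 percentage points lower (beyond the scatter) from compound 1 to compound 2 and a number 15 percentage points lower (beyond the scatter) from compound 3 to compound 4, 1 percentage points apart, within the scatter of two such steps. Thiophen-2-yl in place of furan-3-yl on a saturated ring carbon still gives no step that can be told from the scatter, with a number 3 percentage points higher from compound 2 to compound 4 (within the scatter), and this too matches the earlier pair: the same change on two cores in this assay, a number 4 percentage points higher (within the scatter) from compound 1 to compound 3 and a number 3 percentage points higher (within the scatter) from compound 2 to compound 4, 1 percentage points apart, within the scatter of two such steps. Across these four compounds the two changes therefore appear to act separately, but each rests on only two pairs at a single test concentration, so this does not show that either step would carry over to other cores or how potent any compound is.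

The compounds shown leave open how cyclohexyl or an open chain such as isopropyl would behave on that oxygen. They also leave open whether phenyl on the saturated ring carbon would follow furan-3-yl and thiophen-2-yl.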